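Trifluoromethyl for Fluoro, Tried on a Second Core

The compounds below may be only part of what the source reports. "The series", "measured", "known", "first", "only" and "open" are said of these compounds alone.

Compound 1, `Cc1ccc(-c2nn(-c3ccccc3)cc2-c2nc3ccccc3n2S(=O)(=O)c2ccc(F)cc2)cc1`, gives 5270 nM.
Compound 2, `Cc1ccc(-c2nn(-c3ccccc3)cc2-c2nc3ccccc3n2S(=O)(=O)c2ccc(C(F)(F)F)cc2)cc1`, gives 2340 nM.
Compound 3, `O=S(=O)(c1ccccc1)n1c(-c2cn(-c3ccccc3)nc2-c2ccc(F)cc2)nc2ccccc21`, gives 690 nM.

All three numbers come from a functional assay on MCF7 cells (Homo sapiens) for antiproliferative activity, read by MTT assay, with a stated time of 24 h; a lower number here means a stronger inhibitor, a higher number a weaker inhibitor. Compound 1 and compound 2 share one core and differ in a single place: trifluoromethyl in place of fluoro on an aromatic carbon. That change gave a 2.3-fold lower number from compound 1 to compound 2 (0.35 log units; beyond the scatter), a drop in the number that is beyond the usual scatter of repeated measurements, so it counts as a real gain in potency on this core.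

Compound 3 sits on a different core. How the core of compound 3 differs from the core of compound 1 is not broken down here. What is clear is that compound 3 gives the lowest of the three numbers, and its steps to compound 2 and to compound 1 are both beyond the scatter, so it is the strongest inhibitor of the three.

Compound 4, `O=S(=O)(c1ccccc1)n1c(-c2cn(-c3ccccc3)nc2-c2ccc(C(F)(F)F)cc2)nc2ccccc21`, has not yet been measured in this assay. It relates to compound 3 exactly as compound 2 relates to compound 1: trifluoromethyl in place of fluoro on an aromatic carbon. The place of the change is described in the same words in both pairs, so this is the same change carried onto the second core. The only guide to its size is the earlier step, and so a step of about a 2.2-fold lower number from compound 3 to compound 4 (0.33 log units; beyond the scatter) is expected, resting on compound 1 and compound 2 having shown a 2.3-fold lower number from compound 1 to compound 2 (0.35 log units; beyond the scatter). Whether a gain seen on one core carries over to another is not settled by a single example, so the expected range is kept wide. Compound 4 is therefore estimated at 320 nM, with the likely span running from 120 nM to 900 nM.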

Compound 4, half-maximal inhibitory concentration: 630 nM
Compound 4: middle estimate off by 2.0-fold (0.29 log units), on the low side, within the range that was stated.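

Carried onto the second core, trifluoromethyl in place of fluoro gave a 1.1-fold lower number from compound 3 to compound 4 (0.04 log units; within the scatter), so in this assay compound 3 and compound 4 cannot be told apart. The step on the first core was beyond the scatter and this one is not, yet the two steps themselves cannot be called different: the same change on two cores in this assay, a 2.3-fold lower number (0.35 log units; beyond the scatter) from compound 1 to compound 2 and a 1.1-fold lower number (0.04 log units; within the scatter) from compound 3 to compound 4, 2.1-fold (0.31 log units) apart, within the scatter of two such steps

This result therefore does not show that the gain seen on the first core carries over to the second, and it does not show that the gain is lost there either, since two pairs of compounds are too few to fix a typical size for this change or to say how much that size depends on the core.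

The compounds shown leave open what other groups would do on the same aromatic carbon, such as chloro, methoxy, an amine or a carboxylic acid, each of which could be set against fluoro and trifluoromethyl on both cores. They also leave open whether a third core would give a step like that from compound 1 to compound 2 or one like that from compound 3 to compound 4.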